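Replacing the pendant aryl group of compound 1 with bromo

This account rests on a few compounds, and the source may have more. Where it says the series, first, only, none or still open, it means among the compounds named here.

Among the compounds with values here, compound 1 `O=C(NO)c1ccc(/C=C/c2ccnc(-c3ccccc3O)c2)cc1` gives 47 nM in an assay on isolated protein for inhibition of protein deacetylase HDAC6 (Homo sapiens), read by fluorescence, with a stated time of 15 min (a lower number here means a stronger inhibitor, a higher number a weaker inhibitor), the second highest of the three numbers measured so far. Compound 2 `O=C(NO)c1ccc(/C=C/c2ccnc(-c3cccc(O)c3)c2)cc1` gives 19 nM, and compound 3 `Cc1ccc(-c2cc(/C=C/c3ccc(C(=O)NO)cc3)ccn2)cc1` gives 150 nM. Among the measured steps, a 2.5-fold lower number from compound 1 to compound 2 (0.39 log units; beyond the scatter) and a 3.2-fold higher number from compound 1 to compound 3 (0.50 log units; beyond the scatter); in addition, a 7.9-fold higher number from compound 2 to compound 3 (0.90 log units; beyond the scatter). The unmeasured compound 4 `O=C(NO)c1ccc(/C=C/c2ccnc(Br)c2)cc1` differs from compound 1 in that (bromo in place of 2-hydroxyphenyl on an aromatic carbon). Within the data shown here, none of the measured steps removes the pendant aromatic ring; each only varies its substituent, so they bear on the step to compound 4 only indirectly. The steps from compound 1 to compound 2 and to compound 3 show that alterations at this group move the number by a modest amount in either direction, and the exchange of the whole ring for a single bromine is a larger structural change than any measured here. Compound 4 is therefore expected to be a weaker inhibitor than compound 1, with the expected step being a 4.3-fold higher number from compound 1 to compound 4 (0.63 log units; beyond the scatter). Compound 4 is estimated at 200 nM, within a range of 60 nM to 700 nM.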

Compound 4, half-maximal inhibitory concentration: 320 nM
Estimate against measurement, compound 4: 1.6-fold (0.20 log units) below; the measured number falls inside the stated range.
By their numbers in this assay, from the lowest: compound 2; then compound 1; then compound 3; then compound 4.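

Exchanging the pendant aryl group for bromo raises the number against all three aryl compounds, with a 6.8-fold higher number from compound 1 to compound 4 (0.83 log units; beyond the scatter) and a 2.1-fold higher number from compound 3 to compound 4 (0.33 log units; beyond the scatter) and a 17-fold higher number from compound 2 to compound 4 (1.23 log units; beyond the scatter), so compound 4 is the weakest inhibitor of the four. The earlier compounds shown here varied only the substituent on the pendant ring, whereas compound 4 shows that inhibition persists without that ring, and that each of the three aryl groups gives a lower number than bromo at this position next to the ring nitrogen. Nothing at hand explains the rise in the number with this change.

Open, from the compounds shown here alone, is whether unsubstituted phenyl would retain the lower numbers of the hydroxyphenyl compounds. Also open, going by these compounds, is how a non-aromatic group at this position, such as an amine or a short alkyl chain, would compare with bromo.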